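The source may hold more compounds than are shown below. What is called first, only, known or untested is meant among the compounds shown, and "the series" means these compounds.

In a functional assay on A549 cells (Homo sapiens) for antiproliferative activity, read by MTT assay, with a stated time of 48 h (on this read-out lower numbers stand for stronger inhibition and higher numbers for weaker inhibition), compound 3 `O=[N+]([O-])c1ccc(-c2nn(-c3ccccc3)cc2C(Nc2nc3ccccc3s2)c2c(O)ccc3ccccc23)cc1` gives 41300 nM while compound 1 `O=[N+]([O-])c1cccc(-c2nn(-c3ccccc3)cc2C(Nc2nc3ccccc3s2)c2c(O)ccc3ccccc23)c1` gives 32000 nM and compound 2 `COc1cccc(-c2nn(-c3ccccc3)cc2C(Nc2nc3ccccc3s2)c2c(O)ccc3ccccc23)c1` gives 24800 nM on the same read-out. These three numbers lie within the scatter of one another, so compound 3 cannot be ranked against the other two. Going by the values given here, compound 4 `Cc1ccc(-c2nn(-c3ccccc3)cc2C(Nc2nc3ccccc3s2)c2c(O)ccc3ccccc23)cc1` keeps the shared core and carries methyl in place of nitro on an aromatic carbon as its only change from compound 3. Among the compounds with values here, no measured compound carries this methyl group, so the nearest guide is the size of the other steps, namely a 1.3-fold higher number from compound 1 to compound 3 (0.11 log units; within the scatter) and a 1.7-fold higher number from compound 2 to compound 3 (0.22 log units; within the scatter) and both stay within the scatter. Given the step of a 1.3-fold lower number from compound 1 to compound 2 (0.11 log units; within the scatter) where methoxy replaced nitro, no step beyond the scatter is expected in this assay and neither direction can be firmly favoured. The estimated step is a 1.3-fold lower number from compound 3 to compound 4 (0.12 log units; within the scatter) and it is expected to stay within the scatter. Compound 4 is expected at 31000 nM with an estimated range from 16000 nM to 60000 nM on this read-out.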

Compound 4, half-maximal inhibitory concentration: 57400 nM
Compound 4: the middle estimate sits 1.9-fold (0.27 log units) below what was measured, and the stated range covers the measured number.
By their numbers in this assay, from the lowest: compounds 2, 1, 3 and 4 (each within the scatter of the next, the first and the last beyond it).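

In this assay, replacing nitro with methyl on this ring gives a 1.4-fold higher number from compound 3 to compound 4 (0.14 log units; within the scatter), so removing the nitro group and its hydrogen-bond acceptors does not produce a change that can be told from scatter. Going by these compounds alone, the wider ring swaps give a 1.8-fold higher number from compound 1 to compound 4 (0.25 log units; within the scatter), which also stays within the scatter, and a 2.3-fold higher number from compound 2 to compound 4 (0.36 log units; beyond the scatter), the only step in this set beyond it, though modest; in that step the group and its place on the ring both change. No measurement shown here offers an explanation for any of these steps.

Whether the group or its place on the ring accounts for the gap between 3-methoxyphenyl and 4-methylphenyl stays open. Also open, from the compounds shown here alone, is whether an amine, a carboxylic acid or a longer chain at this position would move the number beyond the scatter from compound 3.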